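A few compounds are considered here, and "the series" means these few. Any claim that something is new, unique, unknown or untested is made for them only; others in the source may bear on it.

Compound 1 `Nc1ccc(-c2cn([C@@H]3CN[C@H](C(=O)Nc4ccc(Cl)c(C(F)(F)F)c4)C3)nn2)cn1`, 10400 nM
Compound 2 `CC(=O)Nc1ccc(-c2cn([C@@H]3CN[C@H](C(=O)Nc4ccc(Cl)c(C(F)(F)F)c4)C3)nn2)cn1`, 8980 nM
Compound 3 `Nc1nc2ccc(-c3cn([C@@H]4CN[C@H](C(=O)Nc5ccc(Br)cc5)C4)nn3)nc2s1`, 24400 nM

All three were tested in a functional assay on K562 cells (Homo sapiens) for inhibition, read by MTT assay, with a stated time of 48 h; on this read-out lower numbers stand for stronger inhibition and higher numbers for weaker inhibition. From compound 1 to compound 2 the change is acetyl in place of hydrogen on a nitrogen on an aromatic ring, and it gave a 1.2-fold lower number from compound 1 to compound 2 (0.06 log units; within the scatter). Compound 3 stands highest of the three; the difference between its core and the core of compound 1 is not broken down here. Compound 4 `CC(=O)Nc1nc2ccc(-c3cn([C@@H]4CN[C@H](C(=O)Nc5ccc(Br)cc5)C4)nn3)nc2s1` is not yet measured; it differs from compound 3 by acetyl in place of hydrogen on a nitrogen on an aromatic ring, the same change, at the same kind of place, as that between compound 1 and compound 2. The step is expected to be a 1.2-fold lower number from compound 3 to compound 4 (0.07 log units; within the scatter), resting on the earlier pair because a 1.2-fold lower number from compound 1 to compound 2 (0.06 log units; within the scatter) stayed within the scatter. Compound 4 is therefore estimated at 21000 nM, with a likely range from 10000 nM to 45000 nM.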

Compound 4, half-maximal inhibitory concentration: 5020 nM
Compound 4: the middle estimate sits 4.2-fold (0.62 log units) above what was measured; measured number outside the range, below it.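

In this assay, acetyl in place of hydrogen on a nitrogen on an aromatic ring gave a 4.9-fold lower number from compound 3 to compound 4 (0.69 log units; beyond the scatter), so the change counts on this core, whereas it made no measurable difference on the core of compound 1: the same change on two cores in this assay, a 1.2-fold lower number (0.06 log units; within the scatter) from compound 1 to compound 2 and a 4.9-fold lower number (0.69 log units; beyond the scatter) from compound 3 to compound 4, 4.2-fold (0.62 log units) apart, beyond the scatter of two such steps

The step therefore cannot be carried at a fixed size from one core to the other in this series. The two pairs differ from each other in more than one place, so they do not show which part of the structure sets the size of the step, or why it changes.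

The compounds shown leave open whether the larger step is particular to acetyl. A longer acyl chain such as propionyl, or a methanesulfonyl group, on the same nitrogen could answer that.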